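Replacing a Cyclobutyl Amide with a Pyridin-4-yl Amide

A few compounds are considered here, and "the series" means these few. Any claim that something is new, unique, unknown or untested is made for them only; others in the source may bear on it.

Within the data shown here, compound 2 `O=C(C1CCC1)N1CCCn2nc(COc3ccccc3)cc21` gives 41% in a functional assay on HEK293 cells for positive allosteric modulation of metabotropic glutamate receptor 5 (Homo sapiens), read by calcium flux (a higher number here means a larger maximal response, a lower number a smaller maximal response), the lower of the two numbers so far; compound 1 `CC(C)C(=O)N1CCCn2nc(COc3ccccc3)cc21` gives 59%. Among the measured compounds shown here, the one measured step, a number 18 percentage points lower from compound 1 to compound 2 (beyond the scatter), concerns a different exchange on the same carbonyl carbon. Compound 3 `O=C(c1ccncc1)N1CCCn2nc(COc3ccccc3)cc21` differs from compound 2 by pyridin-4-yl in place of cyclobutyl on a carbonyl carbon. For the measured compounds named here, no measured step covers an aromatic group at this place, so the direction is open; compound 3 is expected to change by a number 4 percentage points higher from compound 2 to compound 3 (within the scatter), that is, little beyond the scatter. Compound 3 is therefore estimated at 45%, within 25% to 70%.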

Compound 3, largest response reached (reported as percent of maximum), in percent of the reference or control that the assay uses: 51%
The estimate for compound 3 lay 6 percentage points below the measured number; measured number inside the range.
By their numbers in this assay, from the lowest: compounds 2, 3 and 1 (each within the scatter of the next, the first and the last beyond it).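

In this assay, pyridin-4-yl on the carbonyl carbon shows that an aromatic ring can occupy this place, giving a number 10 percentage points higher from compound 2 to compound 3 (within the scatter) and a number 8 percentage points lower from compound 1 to compound 3 (within the scatter) in the same comparison set. Compound 3 thus cannot be separated from either compound 1 or compound 2, even though those two differ beyond the scatter. No evidence is available to explain this result.

As far as these compounds go, whether phenyl or pyridin-3-yl would behave like pyridin-4-yl remains open. So does the outcome with an amine or a longer chain on this carbonyl carbon.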